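Configuration change at one stereocentre: expectation for compound 4

The source may report more compounds than this note shows. Statements on the series, on what has been measured and on what is new or still open speak of the compounds shown alone.

Compound 1 `CC1=NN(c2ccccc2)C(=O)[C@]12C(=O)C=CC[C@@H]2c1cccc(C)c1` gives 8000 nM
Compound 2 `CC1=NN(c2ccccc2)C(=O)[C@@]12C(=O)C=CC[C@H]2c1ccccc1` gives 5500 nM
Compound 3 `CC1=NN(c2ccccc2)C(=O)[C@@]12C(=O)C=CC[C@@H]2c1ccccc1` gives 9310 nM
Compound 4 `CC1=NN(c2ccccc2)C(=O)[C@]12C(=O)C=CC[C@@H]2c1ccccc1` is not yet measured

All three values come from a functional assay on MDA-MB-231 cells (Homo sapiens) for inhibition, read by MTT assay, with a stated time of 72 h (on this read-out higher numbers stand for weaker inhibition and lower numbers for stronger inhibition), and lie within the scatter of one another, so compound 3 is not separated from compound 1 or compound 2. Moving on to compound 4 keeps every atom and bond. The change is the two compounds have the same atoms and bonds and differ only in configuration as drawn: 1 of 2 stereo elements differ; a stereocentre at a saturated ring carbon is drawn R in compound 3 and S in compound 4 and amounts to a stereocentre at a saturated ring carbon being drawn R in compound 3 and S in compound 4.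

Among the compounds with values here, one measured step bears on this, since it too is a change of configuration at a single stereocentre: a 1.7-fold higher number from compound 2 to compound 3 (0.23 log units; within the scatter) is its size, and there the fact that compounds 2 and 3 differ only in the configuration as drawn is the whole structural difference. The centre that changes now is the other of the two, so that step is only a loose guide. No step beyond the scatter is therefore expected in this assay and no direction is favoured. The estimated step is a 1.3-fold lower number from compound 3 to compound 4 (0.12 log units; within the scatter) and the range is kept wide. For compound 4 the estimate is 7000 nM with an expected range from 3000 nM to 15000 nM in this read-out.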

Compound 4, half-maximal inhibitory concentration: 9080 nM
Estimate against measurement, compound 4: 1.3-fold (0.11 log units) below, and the stated range covers the measured number.
By their numbers in this assay, from the lowest: compounds 2, 1, 4 and 3 (each within the scatter of the next).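

In this assay, the second stereocentre now has a measured step of its own, a 1.0-fold lower number from compound 3 to compound 4 (0.01 log units; within the scatter), so inverting this centre does not separate the pair, just as inverting the first did not. Inverting both centres, which gives mirror images, also stays within the scatter, at a 1.7-fold higher number from compound 2 to compound 4 (0.22 log units; within the scatter), so the three stereoisomers without the aromatic methyl are not told apart in this series: the fact that compounds 2 and 4 differ only in the configuration as drawn

Within the data shown here, the one comparison of hydrogen in place of methyl on an aromatic carbon, a 1.1-fold higher number from compound 1 to compound 4 (0.05 log units; within the scatter), shows that this methyl is likewise not separated from hydrogen.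

On these data alone, whether configuration would begin to count with an amine or a carboxylic acid on that aromatic ring remains open. So does whether a longer chain in place of the methyl on the shared core would change this picture.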